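Outer anilide variation: compound 4 from compound 2

The compounds below may be only part of what the source reports. "The series", "measured", "known", "first", "only" and "open" are said of these compounds alone.

Measured so far in a functional assay on A549 cells (Homo sapiens) for inhibition, read by CCK-8 assay, with a stated time of 72 h, tested at 1 uM; on this read-out lower numbers stand for less inhibition of growth and higher numbers for more inhibition of growth at the one concentration tested:
compound 1 `Cc1cccc(NC(=O)C2(C(=O)Nc3ccc(Nc4ncc5cc(C(=O)N(C)C)n(C6CCCC6)c5n4)cc3)CC2)c1`: 35.2%
compound 2 `CN(C)C(=O)c1cc2cnc(Nc3ccc(NC(=O)C4(C(=O)Nc5ccc(Cl)cc5)CC4)cc3)nc2n1C1CCCC1`: 24.7%
compound 3 `CN(C)C(=O)c1cc2cnc(Nc3ccc(NC(=O)C4(C(=O)Nc5cccc(Cl)c5)CC4)cc3)nc2n1C1CCCC1`: 8.3%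

Compound 2 stands second highest of the three numbers in this assay, with compound 1 above it by a number 10.5 percentage points lower from compound 1 to compound 2 (beyond the scatter) and compound 3 below it by a number 16.4 percentage points lower from compound 2 to compound 3 (beyond the scatter). Compound 4 `CN(C)C(=O)c1cc2cnc(Nc3ccc(NC(=O)C4(C(=O)Nc5cccc(Br)c5)CC4)cc3)nc2n1C1CCCC1` is not yet measured. It differs from compound 2 in one place: 3-bromophenyl in place of 4-chlorophenyl on an amide-type nitrogen. The step that bears most on this is the move of chloro from the 4-position to the 3-position, which gave a number 16.4 percentage points lower from compound 2 to compound 3 (beyond the scatter); the exchange of chloro for methyl on an aromatic carbon gave a number 26.9 percentage points lower from compound 1 to compound 3 (beyond the scatter). Nothing here tells bromo apart from chloro. A drop beyond the scatter is therefore expected, of about a number 14.7 percentage points lower from compound 2 to compound 4 (beyond the scatter). Compound 4 is estimated at 10%, between 0% and 24%.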

Compound 4, percent growth inhibition at one concentration: 20.2%
For compound 4 the middle estimate is 10.2 percentage points below the measured one, within the range that was stated.
By their numbers in this assay, from the lowest: compound 3; then compounds 4 and 2 (each within the scatter of the next); then compound 1.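

In this assay bromo and chloro on the aromatic carbon are told apart, with a number 11.9 percentage points higher from compound 3 to compound 4 (beyond the scatter), and 3-bromophenyl in place of 4-chlorophenyl gives a number 4.5 percentage points lower from compound 2 to compound 4 (within the scatter), so the drop seen with 3-chlorophenyl does not carry over to 3-bromophenyl. Bromo in place of methyl gives a number 15 percentage points lower from compound 1 to compound 4 (beyond the scatter), and 3-methylphenyl in compound 1 stays clear of all three halogen-bearing anilides. No measurement available here accounts for the difference between the two halogens.

Open, as far as these compounds go, is whether 3-methoxyphenyl or 3-aminophenyl would follow compound 1 or compound 3. Also open, from the compounds shown here alone, is whether 4-bromophenyl would match compound 2.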